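Phenyl for methoxy on the shared core

The source may hold more compounds than are shown below. What is called first, only, known or untested is meant among the compounds shown, and "the series" means these compounds.

Of the compounds shown here, three have been measured in an assay on HEK293 cells for agonist activity at Toll-like receptor 8 (Homo sapiens), read by reporter gene assay; on this read-out lower numbers stand for an effect already at smaller amounts and higher numbers for an effect only at larger amounts of compound. Compound 1 `CCCCCCn1c(N)nc2ccccc21` gives 3960 nM. In this assay compound 2 `CCCCCn1c(N)nc2cccc(C)c21` gives 6610 nM. Compound 3 `CCCCCn1c(N)nc2c(OC)cccc21` gives 3740 nM. Compound 3 holds the lowest of the three numbers, yet its gaps to compound 1 and to compound 2 both fall within the scatter, so the three compounds read as one level in this assay and no order among them can be stated.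

Compound 4 `CCCCCn1c(N)nc2c(-c3ccccc3)cccc21` has not yet been measured. It differs from compound 3 by phenyl in place of methoxy on an aromatic carbon. Going by the values given here, no pair among the measured compounds shows the effect of this change, as the measured set varies only the chain length and small substituents on the core. The step of a 1.5-fold lower number from compound 3 to compound 4 (0.17 log units; within the scatter) is therefore expected to be modest and of uncertain direction, with a wide range. Compound 4 is estimated at 2500 nM in this assay, between 600 nM and 10000 nM.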

Compound 4, half-maximal effective concentration: "not active" (no number reported)
For compound 4 the study gives words and no number; the estimate stays without a comparison.
By their numbers in this assay, from the lowest: compounds 3, 1 and 2 (each within the scatter of the next).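

Going by these compounds alone, compound 4 is reported only as "not active", without a number, and no step from compound 3 to it can be read. No supporting data bear on this result. The compounds shown leave open how other groups in place of methoxy on this aromatic carbon would read out.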